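The compounds below may be only part of what the source reports. "The series", "measured", "known", "first", "only" and "open" are said of these compounds alone.

Measured compounds: compound 1 `CC(C)c1ccc2c(CCCCS(=O)(=O)Nc3ccccc3)cc(C(=O)O)c-2cc1`, 8700 nM; compound 2 `CC(C)c1ccc2c(CCCCCS(=O)(=O)Nc3ccc(Cl)cc3)cc(C(=O)O)c-2cc1`, 1700 nM.

In a functional assay on thoracic aorta for antagonist activity at thromboxane A2 receptor (Rattus norvegicus) (on this read-out higher numbers stand for weaker inhibition and lower numbers for stronger inhibition), compound 2 holds the lowest of the two numbers; compound 1 gives 8700 nM, a gap beyond the scatter. Compound 3 `CC(C)c1ccc2c(CCCCCS(=O)(=O)Nc3ccc(Cl)cc3)cc(S(=O)(=O)O)c-2cc1` differs from compound 2 by sulfo in place of carboxy on an aromatic carbon. Within the data shown here, no measured pair shows this change, so its effect is unknown. With a larger acid group in the same place, a step of modest size in either direction is expected, most likely toward a somewhat higher number in this assay, as a 2.1-fold higher number from compound 2 to compound 3 (0.31 log units; beyond the scatter). For compound 3 the estimate is 3500 nM, range 900 nM to 14000 nM.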

Compound 3, half-maximal inhibitory concentration: 860 nM
Beside the measured number, compound 3's estimate is 4.1-fold (0.61 log units) above it; measured number below the stated range.
By their numbers in this assay, from the lowest: compounds 3 and 2 (each within the scatter of the next); then compound 1.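

In this assay, among these compounds, sulfo in place of carboxy on an aromatic carbon gives a 2.0-fold lower number from compound 2 to compound 3 (0.30 log units; within the scatter), the first reading of this position. Carboxy is thus not required here for the activity of this pair: with the rest of compound 2 unchanged, sulfo serves equally within the scatter. Nothing in the data available accounts for this result. Open, on these data alone, is whether a phosphono or tetrazolyl group at the same aromatic carbon would also hold this level. Also open, as far as these compounds go, is whether sulfo would do the same on the shorter chain and unsubstituted phenyl of compound 1.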